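The source may hold more compounds than are shown below. What is called first, only, known or untested is meant among the compounds shown, and "the series" means these compounds.

Working notes on the series. In a functional assay on MDA-MB-231 cells (Homo sapiens) for cytotoxicity, read by MTT assay, with a stated time of 72 h (on this read-out lower numbers stand for stronger inhibition and higher numbers for weaker inhibition), compound 1 `CN(C)CCCNc1nc(-c2ccc(NC(=O)Nc3ccccc3F)cc2)nc2ccsc12` gives 660 nM and stands second highest of the three numbers; compound 2 `CN(C)CCCNc1nc(-c2ccc(NC(=O)Nc3ccccc3Cl)cc2)nc2ccsc12` gives 590 nM, and compound 3 `CN(C)CCCNc1nc(-c2ccc(NC(=O)Nc3ccc(Cl)cc3Cl)cc2)nc2c(Cl)c(Cl)sc12` gives 3490 nM. For the measured compounds named here, the one measured step, a 1.1-fold lower number from compound 1 to compound 2 (0.05 log units; within the scatter), changes only the halogen on the aromatic ring. Compound 4 `CN(C)CCNc1nc(-c2ccc(NC(=O)Nc3ccccc3F)cc2)nc2ccsc12` differs from compound 1 by dimethylamino in place of (dimethylamino)methyl on a saturated chain carbon, two bonds along the chain from a nitrogen on an aromatic ring, so the chain is one carbon shorter. Going by the values given here, no measured step touches this chain; the step from compound 1 to compound 2 tells nothing about it, and the gap between compound 1 and compound 3 combines several changes. With no guide, the expectation in this assay is a step of about a 1.2-fold higher number from compound 1 to compound 4 (0.08 log units; within the scatter), not beyond the scatter. Compound 4 is therefore estimated at 800 nM, with a range of 300 nM to 2200 nM.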

Compound 4, half-maximal inhibitory concentration: 600 nM
Compound 4: middle estimate off by 1.3-fold (0.12 log units), on the high side; the measured number falls inside the stated range.
By their numbers in this assay, from the lowest: compounds 2, 4 and 1 (each within the scatter of the next); then compound 3.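

In this assay, for the compounds shown here, the change from (3-(dimethylamino)propyl)amino to (2-(dimethylamino)ethyl)amino gives a 1.1-fold lower number from compound 1 to compound 4 (0.04 log units; within the scatter) and is the first reading at this chain. With the rest of compound 1 unchanged, the two chain lengths are not separated at this position. No measurement shown here offers an explanation for this result.

Still open, from the compounds shown here alone, is how a longer chain, or a morpholine in place of dimethylamino, would read. Also open, going by these compounds, is whether the same shortening reads alike with the substituents of compound 2 or compound 3.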